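A few compounds are considered here, and "the series" means these few. Any claim that something is new, unique, unknown or untested is made for them only; others in the source may bear on it.

Measured compounds:
Compound 1, `CC1=CC[C@H](C(C)(C)NC(=S)N/N=C/c2ccccc2O)CC1`, gives 11200 nM in an ADME assay on Vero cells (Chlorocebus sabaeus) for inhibition, read by sulforhodamine B assay, with a stated time of 48 h; on this read-out higher numbers stand for weaker inhibition of growth and lower numbers for stronger inhibition of growth.
Compound 2, `CC1=CC[C@H](C(C)(C)NC(=S)N/N=C/c2ccc(F)cc2)CC1`, sits at a limit of this assay in this assay: > 100000 nM.
Compound 3, `CC1=CC[C@H](C(C)(C)NC(=S)N/N=C/c2ccc(Cl)cc2)CC1`, also sits at a limit of this assay in this assay: > 100000 nM.

Within the data shown here, compound 1 is thus the only member of this set with a number in this assay; the other two values are limits, as the limit of > 100000 nM in this assay, at which 2 of the 3 values shown sit, records.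

The step to compound 4, `CC1=CC[C@H](C(C)(C)NC(=S)N/N=C/c2ccccc2[N+](=O)[O-])CC1`, is nitro in place of hydroxy on an aromatic carbon. Among the measured compounds shown here, no measured step touches this exact change. The two measured steps from compound 1 both alter the same aromatic ring and both reach a limit: an at least 8.9-fold higher number from compound 1 to compound 2 (0.95 log units; beyond the scatter) and an at least 8.9-fold higher number from compound 1 to compound 3 (0.95 log units; beyond the scatter). Between compound 2 and compound 3 the two limits leave the step unreadable: a step that the two limits leave unreadable from compound 2 to compound 3. As far as these compounds go, both measured departures from the hydroxy group of compound 1 weakened growth inhibition beyond the scatter, so a weakening in this assay is expected for compound 4 as well, though the hydroxy-to-nitro change is untested and the size remains uncertain; the expected step is a 3.6-fold higher number from compound 1 to compound 4 (0.55 log units; beyond the scatter). Compound 4 is estimated at 40000 nM, within 10000 nM to 120000 nM.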

Compound 4, concentration for total growth inhibition: > 100000 nM
Compound 4 ended at the assay's limit; the forecaster's own chance of this, stated with the estimate: 40%; at least 2.5-fold (0.39 log units) between middle value and limit.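

With nitro in place of hydroxy, this assay shows an at least 8.9-fold higher number from compound 1 to compound 4 (0.95 log units; beyond the scatter), although the aromatic ring still carries a group at the same place, ortho to a large group. Compound 2 and compound 3 have no group there, so they could not show that merely filling this place is not enough to keep a number in this read-out: among the compounds shown, only the hydroxy of compound 1 does so. Compound 1 now stands alone with a number, and the values of the other compounds cannot be ordered: the limit of > 100000 nM in this assay, at which 3 of the 4 values shown sit.

As far as these compounds go, how far the nitro step really reaches stays open, since its upper end lies beyond the limit. Also open, from the compounds shown here alone, is whether an amine or a methoxy group at this place would behave like hydroxy or like nitro.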